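A few compounds are considered here, and "the series" means these few. Any claim that something is new, unique, unknown or untested is made for them only; others in the source may bear on it.

Measured so far in a functional assay on CCRF-CEM cells (Homo sapiens) for inhibition, read by cell counting, with a stated time of 3 days; on this read-out higher numbers stand for weaker inhibition and lower numbers for stronger inhibition:
- compound 1 `C=C(Br)C(=O)Nc1cccc(-c2cn3nc(-c4ccc(CC)cc4)sc3n2)c1`: 3400 nM
- compound 2 `C=C(Br)C(=O)Nc1cccc(-c2cn3nc(Cc4ccccc4)sc3n2)c1`: 4200 nM
- compound 3 `C=C(Br)C(=O)Nc1cccc(-c2cn3nc(Cc4ccc(Cl)cc4)sc3n2)c1`: 3300 nM

Compound 2 gives the highest number of the three, but its neighbours sit close: a 1.2-fold higher number from compound 1 to compound 2 (0.09 log units; within the scatter) and a 1.3-fold lower number from compound 2 to compound 3 (0.10 log units; within the scatter) are both within the scatter, as is a 1.0-fold lower number from compound 1 to compound 3 (0.01 log units; within the scatter). The three measured steps all vary the group on the aromatic carbon of the shared core and leave the amide untouched.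

Compound 4 `Nc1cccc(-c2cn3nc(Cc4ccccc4)sc3n2)c1` differs from compound 2 by hydrogen in place of (1-bromoethenyl)carbonyl on a nitrogen on an aromatic ring. Among the measured compounds shown here, no measured step bears on this nitrogen, so the expectation rests on the absence of precedent rather than on a comparison. Removing this group is expected to give a step of a 3.6-fold higher number from compound 2 to compound 4 (0.55 log units; beyond the scatter) toward a weaker number, with wide uncertainty; compound 4 is estimated at 15000 nM (range 3000 nM to 60000 nM).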

Compound 4, half-maximal inhibitory concentration: 37000 nM
Beside the measured number, compound 4's estimate is 2.5-fold (0.39 log units) below it; measured number inside the range.
By their numbers in this assay, from the lowest: compounds 3, 1 and 2 (each within the scatter of the next); then compound 4.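

In this assay, the nitrogen on an aromatic ring is the only position shown where a change goes beyond the scatter: an 8.8-fold higher number from compound 2 to compound 4 (0.94 log units; beyond the scatter). The earlier steps shown here, all on the aromatic carbon, stayed within it, which makes ((1-bromoethenyl)carbonyl)amino to amino the largest change in this set. No measured evidence bearing on this step is available.

Which part of the (1-bromoethenyl)carbonyl group carries the step remains open. An acetyl or acryloyl group on this nitrogen would separate the contributions of the bromine and the double bond from that of the carbonyl.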